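Swapping methoxy for methanesulfonamido on a shared core

The source may report more compounds than this note shows. Statements on the series, on what has been measured and on what is new or still open speak of the compounds shown alone.

Three measured compounds share one core and differ only in the group on its outer ring. In an assay for binding affinity to 17-beta-hydroxysteroid dehydrogenase type 2 (Homo sapiens), with a stated time of 20 min, tested at 1 uM (on this read-out lower numbers stand for less inhibition and higher numbers for more inhibition at the one concentration tested (going by the name of the read-out)), compound 1 `Oc1cccc(-c2ccc3c(O)cccc3c2)c1` gives 32%, compound 2 `COc1ccc(-c2ccc3c(O)cccc3c2)cc1` gives 20% and compound 3 `Oc1cccc2cc(-c3ccncc3)ccc12` gives 26%. Compound 2 thus stands lowest of the three: its number lies within the scatter of that of compound 3, while compound 1 lies beyond the scatter above it. Compound 4 `CS(=O)(=O)Nc1ccc(-c2ccc3c(O)cccc3c2)cc1` has not yet been tested in this assay. It differs from compound 2 by methanesulfonamido in place of methoxy on an aromatic carbon. Since compound 1, which carries a hydrogen-bond donor on that ring, gives the highest measured number at 32%, a modest rise that may still fall within the scatter is expected. A step of a number 10 percentage points higher from compound 2 to compound 4 (within the scatter) is expected. Compound 4 is estimated at 30%, with a range from 12% to 50%.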

Compound 4, a percentage reported as inhibition, at one concentration (the size of the read-out at that concentration, not a potency): 75%
Beside the measured number, compound 4's estimate is 45 percentage points below it, outside the stated range (above it).
By their numbers in this assay, from the lowest: compounds 2, 3 and 1 (each within the scatter of the next, the first and the last beyond it); then compound 4.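

In this assay, methanesulfonamido in place of methoxy on this aromatic carbon, para to a large group, gives a large rise: a number 55 percentage points higher from compound 2 to compound 4 (beyond the scatter). Among the compounds shown here, the read-out therefore responds strongly to the group held at this position, something the earlier compounds could not show, as no two of them differ in one place only. Nothing available here explains the rise. On these data alone, it remains open whether the whole methanesulfonamido group is needed, or whether a simple amine, an acetamido group or the longer ethanesulfonamido group at the same position would give a similar number.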